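This account rests on a few compounds, and the source may have more. Where it says the series, first, only, none or still open, it means among the compounds named here.

Compound 1, `CCC(CC)C(=O)OCC1CN(C(=O)c2cc(OC)c(OC)c(OC)c2)CCN1C(=O)c1cc(OC)c(OC)c(OC)c1`, has been measured three times in a functional assay (Oryctolagus cuniculus) for inhibition of platelet-activating factor receptor (Cavia porcellus) (on this read-out lower numbers stand for stronger inhibition and higher numbers for weaker inhibition), where it gives 70 nM; 40 nM; 60 nM (3 entries); the spread of these repeats, (the several entries of compound 1 in this assay, 70 nM; 40 nM; 60 nM (3 entries)), shows how much a single reading of this kind can move. Compound 2, `COc1cc(C(=O)N2CCN(C(=O)c3cc(OC)c(OC)c(OC)c3)C(COC(=O)CC(C)(C)C)C2)cc(OC)c1OC`, gives 120 nM in this assay. Compound 3, `CCCCCCCCNC(=O)OCC1CN(C(=O)c2cc(OC)c(OC)c(OC)c2)CCN1C(=O)c1cc(OC)c(OC)c(OC)c1`, gives 370 nM, the highest of the two single numbers recorded; the step of a 3.1-fold higher number from compound 2 to compound 3 (0.49 log units; beyond the scatter) is beyond the scatter, so the octylamino carbamate is weaker than the neopentyl ester by a modest but real margin.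

Compound 4, `CCC(C)CNC(=O)OCC1CN(C(=O)c2cc(OC)c(OC)c(OC)c2)CCN1C(=O)c1cc(OC)c(OC)c(OC)c1`, is the next compound. It differs from compound 3 in one place: sec-butyl in place of heptyl on a saturated chain carbon bound to an amide-type nitrogen. The carbamate link stays; only the chain is shortened and branched. Among the compounds with values here, the only measured step bearing on a chain change here is the one from compound 2 to compound 3, which pointed to the longer octyl chain as the weaker partner. Shortening it back toward a branched chain is therefore expected to lower the number somewhat, and compound 4 is estimated at 200 nM in this assay, within 80 nM to 500 nM, so that the expected step of a 1.9-fold lower number from compound 3 to compound 4 (0.27 log units; within the scatter) is of modest size.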

Compound 4, half-maximal inhibitory concentration: 470 nM
The estimate for compound 4 lay 2.4-fold (0.37 log units) below the measured number; measured number inside the range.
By their numbers in this assay, from the lowest: compound 2; then compounds 3 and 4 (each within the scatter of the next).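

Within the carbamates, the long straight chain and the branched one cannot be told apart in this assay: a 1.3-fold higher number from compound 3 to compound 4 (0.10 log units; within the scatter), so trimming octyl to 2-methylbutyl leaves the reading where it was. The neopentyl ester still keeps its edge over this new carbamate, a 3.9-fold higher number from compound 2 to compound 4 (0.59 log units; beyond the scatter), so both carbamates shown, whichever chain they carry, give higher numbers than compound 2. A small gap such as the first deserves little weight, as repeat readings of a single compound show: the several entries of compound 1 in this assay, 70 nM; 40 nM; 60 nM (3 entries)

On these data alone, what remains open is whether the link or the chain sets the gap to compound 2, as both change together in these steps; a carbamate carrying neopentyl on its nitrogen would separate the two. Also open, as far as these compounds go, is how a much shorter chain such as ethyl, or a ring-bearing group such as benzyl, would read on the carbamate.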